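This account rests on a few compounds, and the source may have more. Where it says the series, first, only, none or still open, it means among the compounds named here.

The study follows a small set of compounds in a functional assay on cells for positive allosteric modulation of metabotropic glutamate receptor 5 (Rattus norvegicus), read by calcium flux; a lower number here means that less compound is needed, a higher number that more compound is needed for the effect. Compound 1 `COc1ccc(C(=O)Nc2cc(-c3ccccc3)nn2-c2ccccc2)cc1` gives 54 nM in this assay, the lowest of the two numbers recorded so far. Compound 2 `N#Cc1ccc(C(=O)N(C(=O)c2ccc(C#N)cc2)c2cc(-c3ccccc3)nn2-c2ccccc2)cc1` gives 340 nM in this assay, a higher number than compound 1 by a margin beyond the usual scatter. Compound 3 `O=C(Nc1cc(-c2ccccc2)nn1-c1ccccc1)C1CCCCC1` has not yet been measured in this assay. It differs from compound 1 in a single place: cyclohexyl in place of 4-methoxyphenyl on a carbonyl carbon. Going by the values given here, no measured pair of compounds shows this exchange, so its effect cannot be read from the numbers recorded so far and must be estimated. A modest rise in the number is expected, a step from compound 1 to compound 3 of a 2.8-fold higher number from compound 1 to compound 3 (0.44 log units; beyond the scatter), though a result within the scatter would not be surprising. Compound 3 is therefore estimated at 150 nM in this assay, within a range from 40 nM to 600 nM.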

Compound 3, half-maximal effective concentration: > 10000 nM
Compound 3: no number, only a limit; the forecaster's own chance of this, stated with the estimate: 10%; at least 66-fold (1.82 log units) between middle value and limit.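

Going by these compounds alone, exchanging 4-methoxyphenyl for cyclohexyl on a carbonyl carbon gives an at least 180-fold higher number from compound 1 to compound 3 (2.26 log units; beyond the scatter) in this assay, which shows that the number at this position depends strongly on the group carried there, something no earlier pair could show. Compound 3 gives > 10000 nM, which is a limit of the assay and not a number. As far as these compounds go, the full size of the step therefore stays unknown, because the reading sits at a limit: the limit of > 10000 nM in this assay, at which 1 of the 3 values shown sits.

The exchange removes the aromatic ring and the methoxy oxygen together, and the compounds shown do not separate these two changes. From the compounds shown here alone, it remains open whether an unsubstituted phenyl or a 4-methoxycyclohexyl on the carbonyl carbon would stay close to compound 1 or fall toward compound 3.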